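Adding an Isopropyl Group to an Inactive Amide

The source may report more compounds than this note shows. Statements on the series, on what has been measured and on what is new or still open speak of the compounds shown alone.

Of the compounds shown here, three have been tested so far in an assay on isolated protein for inhibition of tyrosine-protein phosphatase non-receptor type 13 (Homo sapiens), read by spectrophotometry; on this read-out higher numbers stand for weaker inhibition and lower numbers for stronger inhibition. Compound 1, `Oc1cc(-c2ccccc2)ccc1C(O)(C(F)(F)F)C(F)(F)F`, lacks the amide side chain of the others. In this assay compound 1 gives > 500000 nM, which is a limit of the measurement and not a number. Compound 2, `O=C(COc1ccc2cc(C(O)(C(F)(F)F)C(F)(F)F)c(O)cc2c1)Nc1ccccc1`, carries the shared core together with an amide bearing a phenyl group. In this assay compound 2 gives > 20000 nM, again a limit rather than a number. Compound 3, `O=C(COc1ccc2cc(C(O)(C(F)(F)F)C(F)(F)F)c(O)cc2c1)NCc1ccc(F)cc1`, has a 4-fluorobenzyl in place of phenyl on the amide-type nitrogen. In this assay compound 3 gives > 20000 nM, also a limit. The step that the two limits leave unreadable from compound 2 to compound 3 cannot be read because both of its ends sit at the limit of > 20000 nM in this assay, at which 2 of the 3 values shown sit. Compound 2 thus stands at a limit, as do the other two values shown, one of them at the limit of > 500000 nM in this assay, at which 1 of the 3 values shown sits.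

Compound 4, `CC(C)c1ccc(NC(=O)COc2ccc3cc(C(O)(C(F)(F)F)C(F)(F)F)c(O)cc3c2)cc1`, differs from compound 2 in one place: isopropyl in place of hydrogen on an aromatic carbon. Within the data shown here, none of the measured steps is readable, so the data give no size and no direction for the coming step in this assay. The expectation for compound 4 is therefore a step that the limit leaves unreadable from compound 2 to compound 4, most likely ending once more at a limit. Compound 4 is estimated at 30000 nM, within a range from 8000 nM to 200000 nM.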

Compound 4, half-maximal inhibitory concentration: 6500 nM
For compound 4 the middle estimate is 4.6-fold (0.66 log units) above the measured one; the whole stated range lies above it.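

Of the compounds shown, compound 4 is the only one in this assay that gives a number rather than a limit, so the aromatic carbon para to a large group on the amide's phenyl ring is a place where a change registers. Isopropyl in place of hydrogen there gives an at least 3.0-fold lower number from compound 2 to compound 4 (0.48 log units; beyond the scatter), and the wider exchange of 4-isopropylphenyl for 4-fluorobenzyl on the amide nitrogen gives an at least 3.0-fold lower number from compound 3 to compound 4 (0.48 log units; beyond the scatter). The step between compound 2 and compound 3 cannot be read, and the full size of the two new steps stays unknown, because compound 2 and compound 3 both sit at a limit: the limit of > 20000 nM in this assay, at which 2 of the 4 values shown sit.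

Going by these compounds, it remains open whether this gain belongs to isopropyl itself or would also come with another group on the same carbon, such as a methyl, a tert-butyl, a methoxy or a carboxylic acid. On these data alone, it is also open whether isopropyl would give a similar step on the benzyl amide of compound 3, or on a longer chain between the amide nitrogen and the ring.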